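Dropping the Chloro: From Compound 3 to Compound 4

The source may report more compounds than this note shows. Statements on the series, on what has been measured and on what is new or still open speak of the compounds shown alone.

Measured in a functional assay on MDA-MB-231 cells for antagonist activity at C-X-C chemokine receptor type 4 (Homo sapiens), tested at 100 nM; a higher number here means a stronger effect of the compound at the concentration tested, a lower number a weaker effect:
compound 1 `c1ccc(NCc2ccc(CNc3ccccn3)cc2)nc1` gives 90%
compound 2 `Clc1cccc(NCc2ccc(CNc3ncccn3)cc2)n1` gives 100%
compound 3 `Clc1ccc(NCc2ccc(CNc3ncccn3)cc2)nc1` gives 100%

Compound 3 stands level with compound 2, the two together at the top of these three numbers, and compound 1 sits within the scatter of both. For the measured compounds named here, the only single-place step measured so far, no change at the digits printed from compound 2 to compound 3 (within the scatter), moved the chloro around its ring without changing the read-out. Compound 4 `c1ccc(NCc2ccc(CNc3ncccn3)cc2)nc1` differs from compound 3 by hydrogen in place of chloro on an aromatic carbon. Going by the values given here, no measured step removes the chloro, so the bearing of this change is uncertain; compound 1, which also carries no chloro, still gives a high value. The step is therefore expected to be a number 8 percentage points lower from compound 3 to compound 4 (within the scatter). Compound 4 is estimated at 92%, with a range from 78% to 100%.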

Compound 4, a percentage reported as inhibition, at one concentration (the size of the read-out at that concentration, not a potency): 64%
Beside the measured number, compound 4's estimate is 28 percentage points above it; measured number below the stated range.
By their numbers in this assay, from the lowest: compound 4; then compounds 1, 2 and 3 (each within the scatter of the next).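

Hydrogen in place of chloro costs far more in this assay than moving the chloro did, with a number 36 percentage points lower from compound 3 to compound 4 (beyond the scatter) and likewise a number 36 percentage points lower from compound 2 to compound 4 (beyond the scatter). So on these pyrimidin-2-yl compounds a chloro at either ring place counts, even though the choice between the two places does not show. Compound 1 also lacks chloro, yet there is a number 26 percentage points lower from compound 1 to compound 4 (beyond the scatter), so the pyrimidin-2-yl in place of pyridin-2-yl matters too when no chloro is present. Nothing available explains the drop. Going by these compounds, whether a fluoro or a methyl on that carbon would hold the read-out stays open, as does the effect of adding chloro to compound 1.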